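Dichloropurine series: adding chloro on the six-membered ring

The source may hold more compounds than are shown below. What is called first, only, known or untested is meant among the compounds shown, and "the series" means these compounds.

Measured so far in a functional assay on SW-620 cells (Homo sapiens) for cytotoxicity, read by sulforhodamine B assay, with a stated time of 48 h; on this read-out higher numbers stand for lower toxicity in this test and lower numbers for higher toxicity in this test:

Compound 1 `ClCc1ccccc1Cn1cnc2c(Cl)nc(Cl)nc21`: compound 1 gives 810 nM
Compound 2 `ClCc1ccccc1Cn1cnc2c(Cl)ncnc21`: compound 2 gives 26300 nM
Compound 3 `ClCc1cccc(Cn2cnc3c(Cl)ncnc32)c1`: compound 3 gives 8910 nM

Compound 3 stands second highest of the three numbers in this assay. Its nearest neighbour is compound 2, which gives a higher number; compound 1 gives a markedly lower number than compound 3. For the measured compounds named here, compound 2 and compound 3 differ in where the chain sits on the benzene ring, a pair for which no single step is measured.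

Compound 4 `ClCc1cccc(Cn2cnc3c(Cl)nc(Cl)nc32)c1` arises from compound 3 by chloro in place of hydrogen on an aromatic carbon. Going by the values given here, the one measured step that bears on this change is the reverse one, a 32-fold higher number from compound 1 to compound 2 (1.51 log units; beyond the scatter), where the same chloro was taken away. That step was large and beyond the scatter, so for compound 4 a large step in this assay toward a lower number is expected, of roughly the same size in the opposite direction. The expected step for compound 4 is a 25-fold lower number from compound 3 to compound 4 (1.41 log units; beyond the scatter). Compound 4 is therefore estimated at 350 nM, with a range from 110 nM to 1200 nM.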

Compound 4, concentration lethal to 50% of the cells: 7760 nM
The estimate for compound 4 lay 22-fold (1.35 log units) below the measured number; the whole stated range lies below it.
By their numbers in this assay, from the lowest: compound 1; then compounds 4 and 3 (each within the scatter of the next); then compound 2.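

In this assay, chloro in place of hydrogen on the aromatic carbon between two ring nitrogen atoms gives a 1.1-fold lower number from compound 3 to compound 4 (0.06 log units; within the scatter), a step within the scatter. This change therefore does not carry a fixed size from one core to another, and the large step seen earlier holds only for the core of compound 1. The two cores differ in where the chain sits on the benzene ring, and the same change reads very differently on them: the same change on two cores in this assay, a 32-fold higher number (1.51 log units; beyond the scatter) from compound 1 to compound 2 and a 1.1-fold higher number (0.06 log units; within the scatter) from compound 4 to compound 3, 28-fold (1.45 log units) apart, beyond the scatter of two such steps.

Two pairs cannot show whether a further placement of the chain on the benzene ring would follow compound 1 or compound 4. Also open, from the compounds shown here alone, is whether an amine or a methoxy group at this ring carbon would depend on the core in the same way as chloro.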